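Swapping an aromatic ring for a cycloheptyl on the amide

The source may report more compounds than this note shows. Statements on the series, on what has been measured and on what is new or still open speak of the compounds shown alone.

The shared core carries an oxalamide whose far nitrogen bears a variable group. Compound 1 `Cc1nc(C(NC(=O)C(=O)Nc2ccc(F)cc2F)C2CCCCN2)sc1CO` has 2,4-difluorophenyl there; in an ADME assay on MT2 cells (Homo sapiens) for cytotoxicity, read by XTT assay, with a stated time of 4 days (a lower number here means that less compound is tolerated, a higher number that more compound is tolerated), compound 1 gives > 110000 nM, a limit of the assay rather than a number. Compound 2 `Cc1nc(C(NC(=O)C(=O)Nc2ccc(Cl)cc2)C2CCCCN2)sc1CO` carries 4-chlorophenyl, and compound 2 gives > 108000 nM, again a limit. Compound 3 `Cc1ccc(NC(=O)C(=O)NC(c2nc(C)c(CO)s2)C2CCCCN2)cc1F` carries 3-fluoro-4-methylphenyl; in this assay compound 3 gives > 88000 nM, also a limit, so compound 3 stands at a limit like the other two (the limit of > 88000 nM in this assay, at which 1 of the 3 values shown sits). The steps a step that the two limits leave unreadable from compound 1 to compound 2, a step that the two limits leave unreadable from compound 1 to compound 3 and a step that the two limits leave unreadable from compound 2 to compound 3 are all unreadable for the same reason.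

Compound 4 `Cc1nc(C(NC(=O)C(=O)NC2CCCCCC2)C2CCCCN2)sc1CO` differs from compound 3 as follows: cycloheptyl in place of 3-fluoro-4-methylphenyl on an amide-type nitrogen. For the measured compounds named here, no measured step gives a readable size to lean on, so the expectation is only that this assay again reports a limit and that the step that the limit leaves unreadable from compound 3 to compound 4 from compound 3 to compound 4 is not beyond the scatter. Compound 4 is therefore estimated at 100000 nM, with a range from 50000 nM to 200000 nM.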

Compound 4, half-maximal cytotoxic concentration: > 90000 nM
Compound 4 was reported as a limit; the forecaster's own chance of this, stated with the estimate: 85%; the middle value does not contradict the limit.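

In this assay compound 4 gives > 90000 nM, a limit of the assay, so its steps from compound 1, compound 2 and compound 3 cannot be read. The compounds shown leave open whether cycloheptyl and the three aromatic groups on the amide-type nitrogen differ in cytotoxicity.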